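Alkyne-to-alkene swap on a nucleoside core

The source may hold more compounds than are shown below. What is called first, only, known or untested is meant among the compounds shown, and "the series" means these compounds.

Compound 1 `Clc1nc(C#Cc2ccccc2)c2ncn(Cc3ccccc3)c2n1` gives 0.8 ug/mL in a functional assay on K562 cells (Homo sapiens) for inhibition, read by thymidine incorporation, with a stated time of 5 h; a higher number here means a weaker inhibitor, a lower number a stronger inhibitor. For the measured compounds named here, compound 3 `Clc1nc(/C=C/c2ccccc2)c2ncn(Cc3ccccc3)c2n1` carries 2-phenylethenyl in place of 2-phenylethynyl on an aromatic carbon and gives 6 ug/mL; the step of a 7.5-fold higher number from compound 1 to compound 3 (0.88 log units; beyond the scatter) is the only measured instance of this change. Compound 2 `OC[C@H]1OC(n2cnc3c(C#Cc4ccccc4)ncnc32)[C@H](O)[C@@H]1O` gives 0.2 ug/mL and stands lowest of the three measured numbers; how its core differs from that of compound 1 is not broken down here. Compound 4 `OC[C@H]1OC(n2cnc3c(/C=C/c4ccccc4)ncnc32)[C@H](O)[C@@H]1O` is not yet measured and carries 2-phenylethenyl in place of 2-phenylethynyl on an aromatic carbon. This is the same kind of change as that from compound 1 to compound 3, not the same: in compound 1 the site is meta to a chloro group, whereas in compound 2 it is not. The expectation for compound 4 in this assay is a step of a 6.5-fold higher number from compound 2 to compound 4 (0.81 log units; beyond the scatter), a weakening of about the size seen in a 7.5-fold higher number from compound 1 to compound 3 (0.88 log units; beyond the scatter), resting on that single step and on the different core of compound 2 being unaccounted for. Compound 4 is accordingly estimated at 1.3 ug/mL, with a range from 0.4 ug/mL to 4 ug/mL.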

Compound 4, half-maximal inhibitory concentration: 10 ug/mL
Compound 4: middle estimate off by 7.7-fold (0.89 log units), on the low side; measured number above the stated range.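

The change to 2-phenylethenyl in place of 2-phenylethynyl gives a 50-fold higher number from compound 2 to compound 4 (1.70 log units; beyond the scatter) in this assay. For the compounds shown here, both measured pairs move in the same direction, towards weaker inhibition, but the size of the step does not carry from one core to the other: the same change on two cores in this assay, a 7.5-fold higher number (0.88 log units; beyond the scatter) from compound 1 to compound 3 and a 50-fold higher number (1.70 log units; beyond the scatter) from compound 2 to compound 4, 6.7-fold (0.82 log units) apart, beyond the scatter of two such steps This shows that a step measured on one core is a poor guide to the size of the same step on the other, but with only one pair per core it does not show which feature of the cores accounts for the gap, nor whether either step is typical of its core.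

The compounds shown leave open whether the larger step follows from the sugar-bearing core of compound 2 or from the absence of the chloro group, since a core carrying only one of these features does not appear among them. Also open, from the compounds shown here alone, is how the step would behave with an amine in place of the chloro group, or with a saturated 2-phenylethyl group at the same site.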